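The source may hold more compounds than are shown below. What is called first, only, known or untested is meant among the compounds shown, and "the series" means these compounds.

Measured so far, in a functional assay on RAW264.7 cells (Mus musculus) for inhibition, read by Griess assay, with stated times of 1 h and 24 h; on this read-out higher numbers stand for weaker inhibition and lower numbers for stronger inhibition:

compound 1 `CC(C)CCOc1ccccc1C1CC(=O)c2ccccc2O1`: 39200 nM
compound 2 `CC(C)=CCOc1ccccc1C1CC(=O)c2ccccc2O1`: 32700 nM
compound 3 `COc1ccccc1C1CC(=O)c2ccccc2O1`: 47300 nM

Compound 3 gives the highest of the three numbers, yet both gaps to it sit within the scatter: a 1.2-fold higher number from compound 1 to compound 3 (0.08 log units; within the scatter) and a 1.4-fold higher number from compound 2 to compound 3 (0.16 log units; within the scatter). Likewise a 1.2-fold lower number from compound 1 to compound 2 (0.08 log units; within the scatter). The three groups tried so far on the saturated chain carbon bound to an oxygen on the aromatic ring therefore leave the read-out unmoved.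

The next compound, compound 4 `COCOc1ccccc1C1CC(=O)c2ccccc2O1`, alters the same place: methoxy in place of hydrogen on a saturated chain carbon bound to an oxygen on an aromatic ring. All three measured steps bear on it, and none of them went beyond the scatter, so no step beyond the scatter is expected either way; the estimated step is a 1.1-fold lower number from compound 3 to compound 4 (0.02 log units; within the scatter). Compound 4 is thus expected to give about 45000 nM in this assay, with a range from 20000 nM to 100000 nM.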

Compound 4, half-maximal inhibitory concentration: 32600 nM
Compound 4: the middle estimate sits 1.4-fold (0.14 log units) above what was measured, within the range that was stated.
By their numbers in this assay, from the lowest: compounds 4, 2, 1 and 3 (each within the scatter of the next).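

In this assay, going by these compounds alone, methoxy, the first group at this place to carry a hydrogen-bond acceptor, still leaves the read-out within the scatter, with a 1.5-fold lower number from compound 3 to compound 4 (0.16 log units; within the scatter). Set against the two hydrocarbon groups, it gives a 1.0-fold lower number from compound 2 to compound 4 (0.00 log units; within the scatter) and a 1.2-fold lower number from compound 1 to compound 4 (0.08 log units; within the scatter), so hydrogen, isobutyl, 2-methylprop-1-en-1-yl and methoxy on this chain carbon all lie within the scatter of one another. No supporting measurement accounts for this flat result.

From the compounds shown here alone, whether an amine, a carboxylic acid or a longer chain at this place would shift the read-out remains open. So does whether changes elsewhere on the shared core would do so.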